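Lipophilicity notes on a sulfonylacetic acid biaryl series

This account rests on a few compounds, and the source may have more. Where it says the series, first, only, none or still open, it means among the compounds named here.

Measured so far:
compound 1 `Cc1cccc(C)c1-c1cccc(COc2ccc(S(=O)(=O)CC(=O)O)cc2)c1` — 2.49
compound 2 `COCCOc1cc(C)c(-c2cccc(COc3ccc(S(=O)(=O)CC(=O)O)cc3)c2)c(C)c1` — "not determined" (no result reported)
compound 3 `Cc1cc(OCCCS(C)(=O)=O)cc(C)c1-c1cccc(COc2ccc(S(=O)(=O)CC(=O)O)cc2)c1` — "not determined" (no result reported)

Among the compounds with values here, in a physicochemical assay for lipophilicity, using the shake flask method, in phosphate buffer, measured as octanol-water partition, with a stated time of 24 h, at pH 7.4, tested at 100 uM (a lower number here means a more polar compound, a higher number a more lipophilic compound), compound 1 gives 2.49 and is the only member of the series with a number; for compound 2 and compound 3 no result was reported, so no comparison across the series is possible.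

Compound 4 `CCOc1ccc(-c2cccc(COc3ccc(S(=O)(=O)CC(=O)O)cc3)c2)c(Cl)c1` is the next entry for this assay. It differs from compound 1 as follows: 2-chloro-4-ethoxyphenyl in place of 2,6-dimethylphenyl on an aromatic carbon. Within the data shown here, the group that leaves and the group that enters are both single six-membered carbon rings carrying small substituents, and no measured step speaks to this kind of change. The step from compound 1 to compound 4 is expected to be small, if anything a slight rise, and may well stay within the scatter: a number 0.16 log units higher from compound 1 to compound 4 (within the scatter). Compound 4 is therefore estimated at 2.65, with a range of 2.2 to 3.1.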

Compound 4, distribution coefficient: 3.12
Estimate against measurement, compound 4: 0.47 log units below; measured number outside the range, above it.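

In this assay, within the data shown here, the series now shows a number 0.63 log units higher from compound 1 to compound 4 (beyond the scatter), the first readable step at this aromatic carbon, meta to a large group. Exchanging 2,6-dimethylphenyl for 2-chloro-4-ethoxyphenyl thus moves the read-out, even though the entering group is also a single six-membered aromatic ring of carbon only. Nothing available explains the size of this step.

Going by these compounds, the chloro and ethoxy groups enter together, so the share of each stays open. Also open, on these data alone, is how an amine on the same ring would shift the number.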